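From nitro to methoxy: a very short half-life in question

The source may report more compounds than this note shows. Statements on the series, on what has been measured and on what is new or still open speak of the compounds shown alone.

In an ADME assay for pharmacokinetics (a higher number here means that the compound lasts longer, a lower number that the compound disappears faster), compound 1 `CCCn1nnc2c(C(N)=O)ncn2c1=O` gives 2.58 h, and compound 3 `NC(=O)c1ncn2c(=O)n(-c3cccc4ccccc34)nnc12` gives 0.0767 h. Compound 2 `NC(=O)c1ncn2c(=O)n(-c3ccc([N+](=O)[O-])cc3)nnc12` gives only a limit, < 0.0167 h, and not a number. Compound 4 `COc1ccc(-n2nnc3c(C(N)=O)ncn3c2=O)cc1` differs from compound 2 in one place, with methoxy in place of nitro on an aromatic carbon, para to a large group (methoxy in place of nitro on an aromatic carbon). Among the measured compounds shown here, no measured pair shows this change alone, so its size is uncertain. The expectation in this assay leans on compound 3, which also carries an aromatic group in that place and gives 0.0767 h. An upward step beyond the scatter is expected an at least 5.9-fold higher number from compound 2 to compound 4 (0.77 log units; beyond the scatter). Compound 4 is estimated at 0.1 h, with an expected range of 0.03 h to 0.4 h.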

Compound 4, half-life: 1.15 h
Compound 4: middle estimate off by 12-fold (1.06 log units), on the low side, outside the stated range (above it).
By their numbers in this assay, from the lowest: compound 3; then compound 4; then compound 1. At a limit, below all of these: compound 2.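

With methoxy in place of nitro on this aromatic carbon, this assay shows an at least 68-fold higher number from compound 2 to compound 4 (1.83 log units; beyond the scatter). Among the compounds shown here, this is the first pair with a single change, and it shows that the group on this carbon alone can move the half-life a long way. The true size of the step stays unknown, since compound 2 stands at a limit and not at a number: the limit of < 0.0167 h in this assay, at which 1 of the 4 values shown sits.

From the compounds shown here alone, whether other groups on this carbon would behave like methoxy stays open. An amine or a carboxylic acid there could land anywhere relative to compound 4.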